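The compounds below may be only part of what the source reports. "The series", "measured", "known", "first", "only" and "open" are said of these compounds alone.

Measured so far in a functional assay on A549 cells (Homo sapiens) for cytotoxicity, with a stated time of 48 h; on this read-out lower numbers stand for stronger inhibition and higher numbers for weaker inhibition:

- compound 1, `COc1ccc2c(=O)cc(/C=C/[S+](C)[O-])oc2c1`: 2200 nM
- compound 2, `C[S+]([O-])/C=C/c1cc(=O)c2cc(F)ccc2o1`: 2100 nM
- compound 3, `C[S+]([O-])/C=C/c1oc2ccccc2c(=O)c1Cc1ccccc1`: 1300 nM

All three share one core, and their numbers in this assay lie close together: the value of compound 2 sits within the usual scatter of both compound 1 and compound 3, so none of the three can be told apart from the others on this read-out.

The unmeasured compound 4, `CC(C)CC(=O)Oc1ccc2oc(/C=C/[S+](C)[O-])cc(=O)c2c1`, is built from compound 2 by one change: (isobutylcarbonyl)oxy in place of fluoro on an aromatic carbon. A small single-atom group is swapped for a larger ester-bearing group on the fused ring, while the rest of the molecule, including the sulfoxide-bearing side chain, is kept.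

Within the data shown here, no measured pair here shows what such a swap does. Compound 1 carries a different small group on the same ring and gives a value within the scatter of compound 2, so there is no sign that this part of the molecule moves the number much. The step from compound 2 to compound 4 is therefore expected to be small, a 1.2-fold lower number from compound 2 to compound 4 (0.07 log units; within the scatter), with no clear direction beyond the scatter.

Compound 4 is thus estimated at 1800 nM, with a range of 700 nM to 4500 nM.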

Compound 4, half-maximal inhibitory concentration: 2300 nM
Compound 4: middle estimate off by 1.3-fold (0.11 log units), on the low side, and the stated range covers the measured number.
By their numbers in this assay, from the lowest: compounds 3, 2, 1 and 4 (each within the scatter of the next).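

In this assay, among these compounds, the one direct comparison at this aromatic carbon is a 1.1-fold higher number from compound 2 to compound 4 (0.04 log units; within the scatter) and so stays within the usual scatter. Fluoro is a single heavy atom, while (isobutylcarbonyl)oxy has 7 heavy atoms and 2 hydrogen-bond acceptors, so this position accepts a much larger group here without a readable change in the number. The earlier compounds shown here could only hint at this, since no two of them differed in just one place, and none carried a group of this size on this ring.

On these data alone, whether an amine, a carboxylic acid or a longer chain on this same carbon would also leave the number within the scatter remains open. Nothing measured here accounts for the result.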